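Chloro for methoxy on a pyrimidine-type core: a step expected

The compounds below may be only part of what the source reports. "The series", "measured", "known", "first", "only" and "open" are said of these compounds alone.

Measured so far:
Compound 1, `CC(=O)OCCc1c(C)nc(Cl)nc1Cl`: > 100000 nM
Compound 2, `COc1nc(Cl)nc(C)c1CCO`: > 100000 nM
Compound 3, `COc1nc(C)c(CCOC(C)=O)c(OC)n1`: 40000 nM

In a functional assay on HCT-116 cells (Homo sapiens) for antiproliferative activity, read by MTT assay, with a stated time of 24 h (on this read-out lower numbers stand for stronger inhibition and higher numbers for weaker inhibition), compound 1 gives only a limit, > 100000 nM. Compound 2 likewise gives only a limit in this assay, > 100000 nM. For the measured compounds named here, compound 3 is the one compound among the three that gives a number in this assay, 40000 nM, so it stands alone as the measured point from which the next step departs. Going by the values given here, no step between two measured compounds that differ in one place is available here.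

Compound 4, `COc1nc(Cl)nc(C)c1CCOC(C)=O`, differs from compound 3 in one place: chloro in place of methoxy on an aromatic carbon, a chloro in place of methoxy on an aromatic carbon. The change sits between two ring nitrogen atoms, meta to a methoxy group and meta to a methyl group, and para to the acetoxyethyl chain.

Compound 1 and compound 2, which both carry chloro on the shared core, sit at the limit described by the limit of > 100000 nM in this assay, at which 2 of the 3 values shown sit, while compound 3, with two methoxy groups, gives a number. On that basis the step from compound 3 to compound 4 is expected to go toward weaker inhibition, by a 2.0-fold higher number from compound 3 to compound 4 (0.30 log units; within the scatter), and compound 4 is estimated at 80000 nM, within a range from 25000 nM to 250000 nM, with a fair chance that this assay reports only a limit for it.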

Compound 4, half-maximal inhibitory concentration: > 100000 nM
Compound 4 gave a limit, no number (the forecaster's own chance of this, stated with the estimate: 45%); middle value at least 1.2-fold (0.09 log units) from the limit.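

Chloro in place of methoxy on an aromatic carbon, at the place between two ring nitrogen atoms, now has a step of its own: in this assay the change gives an at least 2.5-fold higher number from compound 3 to compound 4 (0.39 log units; beyond the scatter). For the compounds shown here, compound 1 and compound 2 also carry chloro on the shared core, but neither offered a step to a measured number, so this pair is the first to link the number of compound 3 to the methoxy group at this place. Compound 1, compound 2 and compound 4 all carry chloro there, none of the three gives a number, and no compound shown goes against this, though the set is small: the limit of > 100000 nM in this assay, at which 3 of the 4 values shown sit.

The steps from compound 2 to compound 4 and from compound 1 to compound 4 cannot be read, as both ends of each are limits of the assay. As far as these compounds go, whether an amine or a longer ether such as ethoxy at this place would give a number in this assay, and how that number would compare with compound 3 at 40000 nM stays open.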